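A few compounds are considered here, and "the series" means these few. Any claim that something is new, unique, unknown or untested is made for them only; others in the source may bear on it.

Two compounds have so far been measured in a functional assay on B16-F10 cells (Mus musculus) for antiproliferative activity, read by MTT assay, with a stated time of 72 h; a lower number here means a stronger inhibitor, a higher number a weaker inhibitor:

Compound 1, `FC(F)(F)c1ccc(-c2cn(Cc3ccccc3)nn2)cc1`: 35400 nM
Compound 2, `C1=C(c2cn(Cc3ccccc3)nn2)CCCC1`: 45500 nM

Compound 2 carries the highest of the two numbers in this assay, yet its nearest neighbour, compound 1, sits within the scatter of it, so the two cannot be placed in order and neither can be called the weaker inhibitor. Both are weak.

Compound 3, `CCCCc1cn(Cc2ccccc2)nn1`, differs from compound 2 in one place: butyl in place of cyclohex-1-en-1-yl on an aromatic carbon. Within the data shown here, no step between two measured compounds speaks to this kind of exchange, so the expectation rests on the step's modest size and on the weak level at which compound 2 stands. Among the measured compounds shown here, the change swaps one ring-free chain for a small non-aromatic ring without adding a donor or an acceptor, and no measured pair shows that such a swap moves this assay beyond its scatter.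

Compound 3 is therefore expected to give about 55000 nM in this assay, in a range from 20000 nM to 150000 nM. The step from compound 2 to compound 3 is estimated as a 1.2-fold higher number from compound 2 to compound 3 (0.08 log units; within the scatter), within the scatter or slightly toward a weaker inhibitor.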

Compound 3, half-maximal inhibitory concentration: 421000 nM
Compound 3: the middle estimate sits 7.7-fold (0.88 log units) below what was measured; the whole stated range lies below it.
By their numbers in this assay, from the lowest: compounds 1 and 2 (each within the scatter of the next); then compound 3.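

In this assay the exchange of cyclohex-1-en-1-yl for butyl on this aromatic carbon gives a clear loss (a 9.3-fold higher number from compound 2 to compound 3 (0.97 log units; beyond the scatter)), so this position does respond to the group it carries, which the earlier pair alone had not shown. Compound 1 and compound 2 both hold a ring at this place and stand within the scatter of each other, whereas compound 3 is the only one of the three with an open chain there, though a single chain cannot establish a rule. Nothing measured here accounts for the loss.

What stays open is whether the ring itself matters or only the size of the group, since a longer chain such as hexyl and a saturated ring such as cyclohexyl are not among the compounds shown. Going by these compounds, whether a butyl chain ending in an amine or a carboxylic acid would behave like butyl also remains open.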